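Butylamino for tert-butyl on a nitrofuran hydrazide scaffold

A few compounds are considered here, and "the series" means these few. Any claim that something is new, unique, unknown or untested is made for them only; others in the source may bear on it.

Measured compounds:
compound 1, `CC(C)(C)c1ccc(C(=O)N/N=C/c2ccc([N+](=O)[O-])o2)cc1`, gives > 200000 nM in an ADME assay on U2OS cells (Homo sapiens) for cytotoxicity; a higher number here means that more compound is tolerated, a lower number that less compound is tolerated
compound 2, `CCCCCCCCc1ccc(C(=O)N/N=C/c2ccc([N+](=O)[O-])o2)cc1`, gives > 200000 nM
compound 3, `O=C(N/N=C/c1ccc([N+](=O)[O-])o1)C1CCCCC1`, gives 25400 nM

Compound 1 stands at a limit of this assay rather than at a number: the limit of > 200000 nM in this assay, at which 2 of the 3 values shown sit. Compound 2 likewise sits at that limit. Among the compounds with values here, the only measured step, a step that the two limits leave unreadable from compound 1 to compound 2, is therefore unreadable in size. Within the data shown here, compound 3 is the one compound with an actual number here.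

The compound not yet measured is compound 4, `CCCCNc1ccc(C(=O)N/N=C/c2ccc([N+](=O)[O-])o2)cc1`. Relative to compound 1 the change is butylamino in place of tert-butyl on an aromatic carbon. Among the measured compounds shown here, no measured step touches a butylamino group, and the step from the tert-butyl compound that does exist cannot be read. The expectation for compound 4 therefore rests on compound 1 being tolerated up to the limit, so the step of an at least 1.3-fold lower number from compound 1 to compound 4 (0.12 log units; that floor lies within the scatter) is expected to be none beyond the scatter. The estimate for compound 4 in this assay is 150000 nM, with a range from 40000 nM to 200000 nM.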

Compound 4, half-maximal cytotoxic concentration: 12000 nM
Compound 4: middle estimate off by 13-fold (1.10 log units), on the high side; measured number outside the range, below it.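

In this assay, within the data shown here, butylamino on this aromatic carbon gives the first readable change at this position: it brings an at least 16-fold lower number from compound 1 to compound 4 (1.22 log units; beyond the scatter), and it brings an at least 16-fold lower number from compound 2 to compound 4 (1.22 log units; beyond the scatter). The position therefore does not treat every group alike, since a group here can clearly lower the amount of compound that the cells tolerate. The earlier step at this position, between compound 1 and compound 2, cannot be read, and each of these two compounds gives only a limit rather than a number: the limit of > 200000 nM in this assay, at which 2 of the 4 values shown sit.

The compounds shown leave open whether the nitrogen or the butyl chain of butylamino accounts for the drop, which a butoxy group or a plain amine at the same place would help to separate. Also open, from the compounds shown here alone, is how the number moves with a shorter or a longer chain on that nitrogen.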